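Swapping the Aryl Group on Compound 2's Amino Nitrogen

The compounds below may be only part of what the source reports. "The series", "measured", "known", "first", "only" and "open" are said of these compounds alone.

Compound 1 `Cc1cc(N2CCNCC2)nc(SCc2nc3ccccc3[nH]2)n1`: in a functional assay on MGC-803 cells (Homo sapiens) for cytotoxicity, read by MTT assay, with a stated time of 72 h (on this read-out lower numbers stand for stronger inhibition and higher numbers for weaker inhibition), compound 1 gives > 100000 nM, which is a limit of the assay and not a number.
Compound 2 `Cc1cc(Nc2ccc(Br)cc2)nc(SCc2nc3ccccc3[nH]2)n1`: in this assay compound 2 gives 26800 nM.

Compound 2 therefore holds the only number shown in this assay; the one other result is a limit (the limit of > 100000 nM in this assay, at which 1 of the 2 values shown sits). Within the data shown here, the single measured step, an at least 3.7-fold lower number from compound 1 to compound 2 (0.57 log units; beyond the scatter), exchanges the whole substituent on the aromatic carbon and is at least modest in size.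

Compound 3 `COc1ccccc1Nc1cc(C)nc(SCc2nc3ccccc3[nH]2)n1` differs from compound 2 by 2-methoxyphenyl in place of 4-bromophenyl on a nitrogen on an aromatic ring. Among the measured compounds shown here, no measured step bears on an exchange of one aryl group for another on that nitrogen: the only step available replaces piperazin-1-yl with an arylamino group, and it says nothing about which aryl group is preferred once the arylamino group is present. With no guide in either direction, a step of a 1.5-fold higher number from compound 2 to compound 3 (0.17 log units; within the scatter) that stays within the usual scatter is expected. The estimate for compound 3 in this assay is 40000 nM, within an expected range from 10000 nM to 150000 nM, with a real chance that only a limit is reported.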

Compound 3, half-maximal inhibitory concentration: 56200 nM
The estimate for compound 3 lay 1.4-fold (0.15 log units) below the measured number; the range from low to high includes it.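

In this assay, the aryl group on the nitrogen proves not to be freely interchangeable: 2-methoxyphenyl in place of 4-bromophenyl gives a 2.1-fold higher number from compound 2 to compound 3 (0.32 log units; beyond the scatter), a modest step, and it shows that the choice of aryl group matters once the arylamino group is present, which the earlier pair could not show. Measured against the piperazin-1-yl group, (2-methoxyphenyl)amino gives an at least 1.7-fold lower number from compound 1 to compound 3 (0.25 log units; that floor lies within the scatter), so the advantage seen with (4-bromophenyl)amino is not established for this second arylamino group. Compound 1 stands at a limit and not at a number: the limit of > 100000 nM in this assay, at which 1 of the 3 values shown sits.

The step changes both the substituent and its place on the aromatic ring, so the compounds shown do not tell which of the two accounts for the difference, a question that 4-methoxyphenyl or 2-bromophenyl on the same nitrogen would address. On these data alone, it also remains open how a plain phenyl group, a benzyl group or a ring carrying a carboxylic acid would fare at this nitrogen in this assay.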